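Estimating a methylpiperazine swap in a cytotoxicity series

The source may hold more compounds than are shown below. What is called first, only, known or untested is meant among the compounds shown, and "the series" means these compounds.

- compound 1 `COc1ncc(-c2ccc3nc(NC(=O)NCC(=O)N4CCCCC4)nn3c2)cc1NS(=O)(=O)c1ccc(F)cc1`: 570 nM
- compound 2 `COc1ncc(-c2ccc3nc(NC(=O)N4CCCC4)nn3c2)cc1NS(=O)(=O)c1ccc(F)cc1`: 1660 nM
- compound 3 `COc1ncc(-c2ccc3nc(NC(=O)NCC(=O)N4CCCC4)nn3c2)cc1NS(=O)(=O)c1ccc(F)cc1`: 2130 nM

All three numbers come from a functional assay on MCF7 cells (Homo sapiens) for cytotoxicity, read by MTT assay, with a stated time of 72 h; on this read-out higher numbers stand for weaker inhibition and lower numbers for stronger inhibition. Compound 3 cannot be told apart from its nearest neighbour, with a 1.3-fold higher number from compound 2 to compound 3 (0.11 log units; within the scatter). It does stand clearly apart from the lowest number, with a 3.7-fold higher number from compound 1 to compound 3 (0.57 log units; beyond the scatter).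

Compound 4 `COc1ncc(-c2ccc3nc(NC(=O)NCCN4CCN(C)CC4)nn3c2)cc1NS(=O)(=O)c1ccc(F)cc1` replaces (pyrrolidin-1-yl)carbonyl with (4-methylpiperazin-1-yl)methyl on a saturated chain carbon bound to an amide-type nitrogen: (4-methylpiperazin-1-yl)methyl in place of (pyrrolidin-1-yl)carbonyl on a saturated chain carbon bound to an amide-type nitrogen. Going by the values given here, no measured step brings in this group, so the data give no direct guide. The closest evidence is the swap of piperidin-1-yl for pyrrolidin-1-yl on a carbonyl carbon, with a 3.7-fold higher number from compound 1 to compound 3 (0.57 log units; beyond the scatter), and the replacement of the whole (((piperidin-1-yl)carbonyl)methyl)amino group, with a 2.9-fold higher number from compound 1 to compound 2 (0.46 log units; beyond the scatter). Both are modest, so a modest step at most is expected in this assay. Its direction is uncertain, with a slight lean towards a lower number, since compound 1 at 570 nM shows that this series can reach lower values. The estimated step is a 1.8-fold lower number from compound 3 to compound 4 (0.25 log units; within the scatter). For compound 4 the estimated value is 1200 nM, with an expected range from 350 nM to 4000 nM.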

Compound 4, half-maximal inhibitory concentration: 500 nM
Estimate against measurement, compound 4: 2.4-fold (0.38 log units) above; measured number inside the range.
By their numbers in this assay, from the lowest: compounds 4 and 1 (each within the scatter of the next); then compounds 2 and 3 (each within the scatter of the next).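

Changing the end of this chain is not limited to groups joined through a carbonyl: in this assay, (4-methylpiperazin-1-yl)methyl in place of (pyrrolidin-1-yl)carbonyl on a saturated chain carbon bound to an amide-type nitrogen gives a 4.3-fold lower number from compound 3 to compound 4 (0.63 log units; beyond the scatter), a step beyond the scatter. The change from the pyrrolidin-1-yl group set directly on the carbonyl carbon also lies beyond the scatter, with a 3.3-fold lower number from compound 2 to compound 4 (0.52 log units; beyond the scatter), whereas the change from (piperidin-1-yl)carbonyl gives a 1.1-fold lower number from compound 1 to compound 4 (0.06 log units; within the scatter), so two quite different end groups cannot be told apart here. No measurement shown gives a reason for these differences.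

The compounds shown leave open whether the gain follows the loss of the carbonyl or the arrival of the second ring nitrogen. The pairing of (pyrrolidin-1-yl)methyl with (4-methylpiperazin-1-yl)carbonyl at this place would separate those two changes.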